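Removing the fluoro from compound 2

This account rests on a few compounds, and the source may have more. Where it says the series, first, only, none or still open, it means among the compounds named here.

Values measured in a functional assay on RPMI-8226 cells (Homo sapiens) for cytotoxicity, read by MTT assay, with a stated time of 48 h (on this read-out lower numbers stand for stronger inhibition and higher numbers for weaker inhibition), are these:

- Compound 1 `FC(F)(F)c1cccc(NN=C2C(Cl)=C(Cl)C(Cl)=C2Cl)c1` gives 110 nM
- Compound 2 `Fc1ccc(NN=C2C(Cl)=C(Cl)C(Cl)=C2Cl)cc1` gives 600 nM

Compound 2 holds the higher of the two numbers, and its gap to compound 1 lies beyond the usual scatter. Compound 3 `ClC1=C(Cl)C(Cl)=C(Cl)C1=NNc1ccccc1` has not yet been measured in this assay and is the next step from compound 2. The change is hydrogen in place of fluoro on an aromatic carbon and, in words, hydrogen in place of fluoro on an aromatic carbon. The rest of the structure stays the same. Among the compounds with values here, no measured pair of compounds differs in one place only, so the data give no direct precedent for the size of this change. Resting on compound 2 at 600 nM as the closest measured structure, a small move to a higher number is expected, quite possibly none beyond the scatter. The expected size is a 1.4-fold higher number from compound 2 to compound 3 (0.15 log units; within the scatter) on this estimate. Compound 3 is expected at 850 nM as a middle value, with an estimated range from 300 nM to 2400 nM as its upper end.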

Compound 3, half-maximal inhibitory concentration: 600 nM
Compound 3: the middle estimate sits 1.4-fold (0.15 log units) above what was measured; the measured number falls inside the stated range.
By their numbers in this assay, from the lowest: compound 1; then compounds 2 and 3 (each within the scatter of the next).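

In this assay, hydrogen in place of fluoro para to a large group gives no change at the digits printed from compound 2 to compound 3 (within the scatter), so at this position the fluoro can be lost without a visible cost on this read-out. Within the data shown here, the same compound 3 also provides the first comparison of trifluoromethyl in one place only: hydrogen in place of that group gives a 5.5-fold higher number from compound 1 to compound 3 (0.74 log units; beyond the scatter), which shows that the trifluoromethyl of compound 1 is linked to a difference that the fluoro of compound 2 does not show. No measurement at hand accounts for either step or for the contrast between them.

The compounds shown leave open whether the lower number of compound 1 belongs to trifluoromethyl itself or also depends on where that group stands on the aromatic ring, since the fluoro and the trifluoromethyl are not compared at one shared position. They also leave open how a methoxy group, an amine or a carboxylic acid on that ring would read in this assay, and whether any of these would match compound 1 or stay level with compound 3.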